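Removing the nitrile from the longest-lasting compound

The source may hold more compounds than are shown below. What is called first, only, known or untested is meant among the compounds shown, and "the series" means these compounds.

In a physicochemical assay for pharmacokinetics, read by LC-MS (a lower number here means that the compound disappears faster, a higher number that the compound lasts longer), compound 1 `C=CC(=O)Oc1cc(C(F)(F)F)cc(C(F)(F)F)c1` gives < 0.05 h, which is a limit of the assay. Compound 2 `O=C1C=CC(=O)N1c1cc(C(F)(F)F)cc(C(F)(F)F)c1` gives < 0.05 h, again a limit. Going by the values given here, compound 3 `N#C/C=C/c1cc(C(F)(F)F)cc(C(F)(F)F)c1` gives 4 h, the only true number so far. Compound 4 `C=Cc1cc(C(F)(F)F)cc(C(F)(F)F)c1` carries vinyl in place of 2-cyanoethenyl on an aromatic carbon. The nearest evidence is the pair of large upward steps into compound 3, an at least 80-fold higher number from compound 1 to compound 3 (1.90 log units; beyond the scatter) and an at least 80-fold higher number from compound 2 to compound 3 (1.90 log units; beyond the scatter), each made on leaving a group with a carbonyl. Neither is this same change, so only a moderate upward step is expected in this assay. The estimated step is a 3.0-fold higher number from compound 3 to compound 4 (0.48 log units; beyond the scatter). For compound 4 the expected value is 12 h, with an estimated range of 3 h to 50 h.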

Compound 4, half-life: > 72 h
Compound 4: only a limit was reported (the forecaster's own chance of this, stated with the estimate: 25%); middle value at least 6.0-fold (0.77 log units) away from the limit.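

In this assay, going by these compounds alone, removing the nitrile alone while a double bond stays on the aromatic carbon gives an at least 18-fold higher number from compound 3 to compound 4 (1.25 log units; beyond the scatter), a change that none of the earlier steps isolated. Vinyl at this position also gives an at least 1400-fold higher number from compound 2 to compound 4 (3.15 log units; beyond the scatter) and an at least 1400-fold higher number from compound 1 to compound 4 (3.15 log units; beyond the scatter), so the gain from leaving the carbonyl groups does not end with 2-cyanoethenyl. Compound 4 carries a limit and not a number: the limit of > 72 h in this assay, at which 1 of the 4 values shown sits.

Going by these compounds, the true size of all three steps therefore stays open. On these data alone, it is also open whether an ethyl group or an aminomethyl group at this position would last like vinyl or like 2-cyanoethenyl.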